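The compounds below may be only part of what the source reports. "The series", "measured", "known", "first", "only" and "open" are said of these compounds alone.

Compound 1 `Cc1c[se]c(NNC(=O)c2ccccc2)n1` and compound 2 `O=C(NNc1nc(-c2ccccc2)c[se]1)c1ccccc1` share one core; compound 2 differs by phenyl in place of methyl on an aromatic carbon. In a functional assay on DU-145 cells (Homo sapiens) for cytotoxicity, read by XTT assay, with a stated time of 72 h (on this read-out lower numbers stand for stronger inhibition and higher numbers for weaker inhibition), compound 1 gives only a limit, > 89200 nM. In this assay compound 2 also gives only a limit, > 73000 nM. The step that the two limits leave unreadable from compound 1 to compound 2 is therefore unreadable, both ends sitting at limits, as the limit of > 89200 nM in this assay, at which 1 of the 3 values shown sits, and the limit of > 73000 nM in this assay, at which 1 of the 3 values shown sits, show. Compound 3 `CC(=O)N(C(=O)c1ccccc1)N(C(C)=O)c1nc(C)c[se]1` carries a different core; the difference between the two cores is not broken down here. In this assay compound 3 gives only a limit, > 68600 nM (the limit of > 68600 nM in this assay, at which 1 of the 3 values shown sits). Compound 4 `CC(=O)N(C(=O)c1ccccc1)N(C(C)=O)c1nc(-c2ccccc2)c[se]1` differs from compound 3 by the same change, (phenyl in place of methyl on an aromatic carbon). The step that the limit leaves unreadable from compound 3 to compound 4 is expected to be small, an expectation resting on the unreadable a step that the two limits leave unreadable from compound 1 to compound 2 and on the limit of compound 3 at > 68600 nM. Compound 4 is estimated at 80000 nM, between 30000 nM and 150000 nM.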

Compound 4, half-maximal inhibitory concentration: > 58600 nM
Compound 4 gave a limit, no number (the forecaster's own chance of this, stated with the estimate: 80%); the middle value lies beyond the limit too.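

Compound 3 and compound 4 both give only limits in this assay, so no step can be read between them. The compounds shown leave open whether phenyl in place of methyl on an aromatic carbon changes cytotoxicity in this assay at all.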